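From bromo to iodo in the antiproliferative series

A few compounds are considered here, and "the series" means these few. Any claim that something is new, unique, unknown or untested is made for them only; others in the source may bear on it.

Of the compounds shown here, two have been measured so far. In a functional assay on LNCaP cells (Homo sapiens) for antiproliferative activity (on this read-out lower numbers stand for stronger inhibition and higher numbers for weaker inhibition), compound 1 (`O=C1NC(O)C(F)=CN1[C@H]1C=C[C@@H](CO)O1`) gives 67800 nM. Compound 2 (`Nc1nc(=O)n([C@H]2C=C[C@@H](CO)O2)cc1Br`) reads > 100000 nM, and this is a limit of the assay, not a number. Compound 2 therefore has a position in the series but no exact value to serve as a starting point.

Compound 3 (`Nc1nc(=O)n([C@H]2C=C[C@@H](CO)O2)cc1I`) differs from compound 2 in one place: iodo in place of bromo on an aromatic carbon. This puts iodo in place of bromo on an aromatic carbon, ortho to an amino group. Among the measured compounds shown here, no measured pair shows what this exchange does. In this assay, the expected step of a number no higher from compound 2 to compound 3 (the limit leaves the size open) is no larger than the scatter, with no direction favoured. A further reading at the limit of the assay would fit this expectation. Compound 3 is estimated at 100000 nM, with an expected range of 40000 nM to 250000 nM.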

Compound 3, half-maximal inhibitory concentration: > 100000 nM
Compound 3 was reported as a limit; the forecaster's own chance of this, stated with the estimate: 65%; the middle value sits exactly at the limit.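

No step can be read between compound 2 and compound 3, because both readings are limits of the assay and not numbers: the limit of > 100000 nM in this assay, at which 2 of the 3 values shown sit.

The compounds shown leave open what iodo in place of bromo does to antiproliferative activity on the shared core.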